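The compounds below may be only part of what the source reports. "The series", "measured", "known", "first", "only" and "open" are said of these compounds alone.

Of the compounds shown here, three sharing one core have been read in a functional assay on VCaP cells (Homo sapiens) for antiproliferative activity, read by CCK-8 assay, with a stated time of 6 days; on this read-out higher numbers stand for weaker inhibition and lower numbers for stronger inhibition. Compound 1 (`CC(O)c1cccc(C(=O)N[C@@H](C)Cn2ccc(-c3ccc(C#N)c(Cl)c3)n2)c1`) gives 900 nM and compound 2 (`CC(=O)c1ccc(C(=O)N[C@@H](C)Cn2ccc(-c3ccc(C#N)c(Cl)c3)n2)cc1`) gives 1400 nM. The a 1.6-fold higher number from compound 1 to compound 2 (0.19 log units; within the scatter) leaves these two indistinguishable. Compound 3 (`C[C@@H](Cn1ccc(-c2ccc(C#N)c(Cl)c2)n1)NC(=O)C1CC(=O)C1`) gives 22500 nM, the highest number of the three and thus the weakest inhibition in the set.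

Compound 4 (`C[C@@H](Cn1ccc(-c2ccc(C#N)c(Cl)c2)n1)Nc1ccncc1`) has not yet been measured. Its difference from compound 3 is this: pyridin-4-yl in place of (3-oxocyclobutyl)carbonyl on an amine nitrogen. Put simply, pyridin-4-yl stands in place of (3-oxocyclobutyl)carbonyl on an amine nitrogen.

For the measured compounds named here, no measured step makes this exact change, so the evidence is indirect. The closest guides are the two steps that end at compound 3, both of which introduce the 3-oxocyclobutyl group: a 25-fold higher number from compound 1 to compound 3 (1.40 log units; beyond the scatter) and a 16-fold higher number from compound 2 to compound 3 (1.21 log units; beyond the scatter). Both are large, and both mark the ring-bearing partners as the stronger inhibitors. Compound 4 also carries an aromatic ring, but it lacks the carbonyl present in all three measured compounds, so only part of that gap is expected to be recovered. The expected change is a 6.4-fold lower number from compound 3 to compound 4 (0.81 log units; beyond the scatter), a move toward stronger inhibition. For compound 4 the estimated value is 3500 nM, with an expected range of 700 nM to 16000 nM.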

Compound 4, half-maximal inhibitory concentration: 9900 nM
Compound 4: middle estimate off by 2.8-fold (0.45 log units), on the low side, and the stated range covers the measured number.
By their numbers in this assay, from the lowest: compounds 1 and 2 (each within the scatter of the next); then compound 4; then compound 3.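

In this assay, the exchange on the amine nitrogen gives a 2.3-fold lower number from compound 3 to compound 4 (0.36 log units; beyond the scatter) and so a modest move toward stronger inhibition, which shows that this nitrogen can carry a pyridin-4-yl ring directly, with no carbonyl on it, and still read better than the (3-oxocyclobutyl)carbonyl group. The aromatic ring alone does not bring the number down to those of the carbonyl-linked aromatic compounds, since compound 4 at 9900 nM stays above compound 1 at 900 nM and compound 2 at 1400 nM in the order of this read-out. Nothing given here accounts for the size of this step.

The step swaps the ring and removes the carbonyl in a single move, so the compounds shown cannot separate what each of these two parts contributes. A pyridin-4-ylcarbonyl group on the same nitrogen would keep the carbonyl with this ring, and a phenyl group attached directly would drop the ring nitrogen, so either one would show which part sets the distance between compound 4 and compound 1.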